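The compounds below may be only part of what the source reports. "The series", "measured", "known", "first", "only" and "open" are said of these compounds alone.

Compound 1 `Cc1ccc(-n2nccn2)c(C(=O)N(CCn2ccc(-c3ccc(F)cn3)n2)C(C)C)c1` gives 38.5 nM in a functional assay on CHO cells for antagonist activity at Orexin/Hypocretin receptor type 1 (Homo sapiens), read by fluorescence and calcium flux, with a stated time of 30 min; a higher number here means a weaker inhibitor, a lower number a stronger inhibitor. Compound 2 `CCN(CCn1ccc(-c2ccc(F)cn2)n1)C(=O)c1cc(F)ccc1-n1nccn1` gives 6.67 nM in this assay, and compound 3 `CCN(CCn1ccc(-c2ccc(F)cn2)n1)C(=O)c1cc(Cl)ccc1-n1nccn1` gives 1.48 nM in this assay, the lowest of the three numbers shown and the strongest inhibitor measured here. Within the data shown here, the one step that changes the same place, a 4.5-fold lower number from compound 2 to compound 3 (0.65 log units; beyond the scatter), shows that swapping one halogen for another at this site matters. Compound 4 `CCN(CCn1ccc(-c2ccc(F)cn2)n1)C(=O)c1cc(OC)ccc1-n1nccn1` differs from compound 3 by methoxy in place of chloro on an aromatic carbon. Among the measured compounds shown here, no measured step involves methoxy, so the earlier step hints only that this site is sensitive, not in which direction. A small rise in the number is expected, with the expected step being a 2.4-fold higher number from compound 3 to compound 4 (0.37 log units; beyond the scatter). Compound 4 is estimated at 3.5 nM, within a range from 1.2 nM to 12 nM.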

Compound 4, antagonist equilibrium constant: 119 nM
For compound 4 the middle estimate is 34-fold (1.53 log units) below the measured one, outside the stated range (above it).
By their numbers in this assay, from the lowest: compound 3; then compound 2; then compound 1; then compound 4.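

At the position para to the 2H-1,2,3-triazol-2-yl group, methoxy proves far less favourable in this assay than either halogen, with an 80-fold higher number from compound 3 to compound 4 (1.91 log units; beyond the scatter) and an 18-fold higher number from compound 2 to compound 4 (1.25 log units; beyond the scatter). Both steps are larger than the change between the two halogens, so this site's sensitivity extends well beyond that swap. No measurement here explains the loss. Still open, going by these compounds, is whether a bromine, a hydroxyl or an amine at this position would give a number close to those of the halogens or to that of methoxy.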